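The compounds below may be only part of what the source reports. "The series", "measured", "known", "first", "only" and "open" are said of these compounds alone.

Compound 1, `C[C@H](NC(=O)C(=O)NCc1ccc(Cl)cc1)C(=O)N[C@@H](CC(=O)O)C(=O)COc1c(F)c(F)cc(F)c1F`, gives 8.4 nM in a functional assay on Jurkat cells (Homo sapiens); a higher number here means a weaker inhibitor, a lower number a stronger inhibitor. Compound 2, `Cc1ccc(CNC(=O)C(=O)N[C@@H](C)C(=O)N[C@@H](CC(=O)O)C(=O)COc2c(F)c(F)cc(F)c2F)c(C)c1`, gives > 10000 nM in this assay.

Going by the values given here, compound 1 holds the only number seen in this assay. The value of compound 2 is a limit of the assay, not a number, and the evidence is the limit of > 10000 nM in this assay, at which 1 of the 2 values shown sits. The measured step of an at least 1100-fold higher number from compound 1 to compound 2 (3.07 log units; beyond the scatter) is large. Compound 3 is `C[C@H](NC(=O)C(=O)NCc1cccc(Cl)c1Cl)C(=O)N[C@@H](CC(=O)O)C(=O)COc1c(F)c(F)cc(F)c1F`, and it differs from compound 1 by 2,3-dichlorophenyl in place of 4-chlorophenyl on a saturated chain carbon bound to an amide-type nitrogen. That step from compound 1 to compound 2 bears on this change, as it also replaced the 4-chlorophenyl at the same place, though with 2,4-dimethylphenyl rather than 2,3-dichlorophenyl. A weakening is therefore expected for compound 3, estimated at a 9.5-fold higher number from compound 1 to compound 3 (0.98 log units; beyond the scatter). Compound 3 is expected to give about 80 nM, most likely between 10 nM and 2000 nM.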

Compound 3, half-maximal inhibitory concentration: 76 nM
Compound 3: the middle estimate sits 1.1-fold (0.02 log units) above what was measured; the measured number falls inside the stated range.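

Replacing 4-chlorophenyl with 2,3-dichlorophenyl at this place in this assay costs far less than the change to 2,4-dimethylphenyl did (a 9.0-fold higher number from compound 1 to compound 3 (0.96 log units; beyond the scatter)), and compound 1 remains the strongest of the three. The two replacements themselves lie far apart (an at least 130-fold lower number from compound 2 to compound 3 (2.11 log units; beyond the scatter)). The value of compound 2 is a limit of the assay, not a number: the limit of > 10000 nM in this assay, at which 1 of the 3 values shown sits.

Going by these compounds, whether the loss in compound 2 comes from its methyl groups remains open. Also open, on these data alone, is how an unsubstituted phenyl, a 4-methylphenyl or a 4-methoxyphenyl would behave at this place.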